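This account rests on a few compounds, and the source may have more. Where it says the series, first, only, none or still open, it means among the compounds named here.

Measured so far in a functional assay on HL-60 cells (Homo sapiens) for cytotoxicity; on this read-out higher numbers stand for weaker inhibition and lower numbers for stronger inhibition:
- compound 1 `CC1(C)CCC(C)(C)c2cc(/C=C/c3ccc(N)cc3)ccc21`: 18000 nM
- compound 2 `COc1ccc(/C=C\c2ccc3c(c2)C(C)(C)CCC3(C)C)cc1N`: 25000 nM
- compound 3 `COc1ccc(/C=C\c2ccc3c(c2)C(C)(C)CCC3(C)C)cc1`: 50000 nM

Compound 3 gives the highest of the three numbers in this assay. Its nearest neighbour is compound 2, and the step of a 2.0-fold higher number from compound 2 to compound 3 (0.30 log units; within the scatter) stays within the scatter; against compound 1 the gap is larger and lies beyond the scatter.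

The next compound, compound 4 `CC1(C)CCC(C)(C)c2cc(/C=C\c3ccc(N)cc3)ccc21`, follows from compound 3 by amino in place of methoxy on an aromatic carbon. Within the data shown here, no measured step covers this exchange directly: the one step available, a 2.0-fold higher number from compound 2 to compound 3 (0.30 log units; within the scatter), removes an amino group while a methoxy group stays in place, and it was small. Compound 4 differs only in the geometry of the double bond from the compound that carries the 4-aminophenyl group, and that compound, compound 1, gives 18000 nM, the lowest number seen.

On that basis compound 4 is expected to land near compound 1, and the step of a 2.5-fold lower number from compound 3 to compound 4 (0.40 log units; beyond the scatter) is estimated as a modest move toward lower numbers, near the edge of the scatter. For compound 4 the estimate is 20000 nM, within 8000 nM to 50000 nM.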

Compound 4, half-maximal inhibitory concentration: 18000 nM
Compound 4: middle estimate off by 1.1-fold (0.05 log units), on the high side; measured number inside the range.
By their numbers in this assay, from the lowest: compounds 1, 4, 2 and 3 (each within the scatter of the next, the first and the last beyond it).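

In this assay, among these compounds, exchanging 4-methoxyphenyl for 4-aminophenyl gives a 2.8-fold lower number from compound 3 to compound 4 (0.44 log units; beyond the scatter), the first one-place exchange to lie beyond the scatter, whereas a 2.0-fold higher number from compound 2 to compound 3 (0.30 log units; within the scatter) stayed within it. Changing the double bond from E to Z gives no change at the digits printed from compound 1 to compound 4 (within the scatter), so with 4-aminophenyl in place, the geometry of the double bond leaves the read-out within the scatter. This comparison reads on geometry alone, and it rests on one point: the fact that compounds 1 and 4 differ only in the configuration as drawn.

Going by these compounds, whether geometry matters as little with 4-methoxyphenyl on the double bond remains open. Also open, on these data alone, is how other groups would read at this place on the aromatic ring, for example a hydroxyl, a dimethylamino group or an acetamide.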